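Swapping an aryl carbonyl for methylsulfonyl on a pyrazoline nitrogen

The source may hold more compounds than are shown below. What is called first, only, known or untested is meant among the compounds shown, and "the series" means these compounds.

Measured compounds:
- compound 1, `CN(C)c1ccc(C2CC(c3ccc(-n4cncn4)cc3)=NN2C(=O)CCCl)cc1`, gives 3.7% in a functional assay on MDA-MB-231 cells (Homo sapiens) for inhibition, read by sulforhodamine B assay, tested at 10 uM; a lower number here means less inhibition, a higher number more inhibition at the concentration tested (going by the name of the read-out)
- compound 2, `COC(=O)CC(=O)N1N=C(c2ccc(-n3cncn3)cc2)CC1c1ccc(N(C)C)cc1`, gives 6.8% in this assay
- compound 3, `CN(C)c1ccc(C2CC(c3ccc(-n4cncn4)cc3)=NN2C(=O)c2ccc(C(F)(F)F)cc2)cc1`, gives 16.7% in this assay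

Compound 3 has the highest of the three numbers; its gap to compound 2 lies within the scatter, while its gap to compound 1 lies beyond it. The three compounds share a core and differ only in the group attached to the amine nitrogen in the ring. Compound 4, `CN(C)c1ccc(C2CC(c3ccc(-n4cncn4)cc3)=NN2S(C)(=O)=O)cc1`, has not been measured; it differs from compound 3 by methylsulfonyl in place of (4-(trifluoromethyl)phenyl)carbonyl on an amine nitrogen in a ring.

Among the measured compounds shown here, two measured steps bear on this change, since both alter the group on the carbonyl carbon: a number 13 percentage points higher from compound 1 to compound 3 (beyond the scatter) and a number 9.9 percentage points higher from compound 2 to compound 3 (within the scatter). For the measured compounds named here, both point the same way, a larger aromatic group giving a somewhat higher number, though only one step clears the scatter. Compound 4 drops the aromatic ring entirely, so a modest fall back toward the values of compound 1 and compound 2 is expected, as a number 8.7 percentage points lower from compound 3 to compound 4 (within the scatter). For compound 4 the estimate is 8%, with a range from 0% to 20%.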

Compound 4, a percentage reported as inhibition, at one concentration (the size of the read-out at that concentration, not a potency): 7.8%
Estimate against measurement, compound 4: 0.2 percentage points above; the measured number falls inside the stated range.
By their numbers in this assay, from the lowest: compounds 1, 2, 4 and 3 (each within the scatter of the next, the first and the last beyond it).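

In this assay, methylsulfonyl on the amine nitrogen in the ring, in place of (4-(trifluoromethyl)phenyl)carbonyl, gives a number 8.9 percentage points lower from compound 3 to compound 4 (within the scatter), so the two groups cannot be told apart here. Set against the other two groups, methylsulfonyl gives a number 1 percentage points higher from compound 2 to compound 4 (within the scatter) and a number 4.1 percentage points higher from compound 1 to compound 4 (within the scatter); compound 4, the only one with no carbonyl on this nitrogen, therefore lies within the scatter of all three earlier compounds, even though compound 1 and compound 3 lie beyond the scatter of each other. Nothing available explains these numbers.

On these data alone, it remains open whether phenylsulfonyl, which joins a sulfonyl to an aromatic ring, would stand apart from methylsulfonyl. Also open, as far as these compounds go, is how a plain ethyl group on this nitrogen, with neither carbonyl nor sulfonyl, would read out.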